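A few compounds are considered here, and "the series" means these few. Any claim that something is new, unique, unknown or untested is made for them only; others in the source may bear on it.

Compound 2 `N#Cc1cnc(NCc2cnccc2C(F)(F)F)cc1NCC1CCOCC1` gives 400 nM in an assay on isolated protein for inhibition of protein kinase C theta type (Homo sapiens), read by TR-FRET, with a stated time of 2 h (on this read-out higher numbers stand for weaker inhibition and lower numbers for stronger inhibition), the highest of the three numbers. Compound 1 `CO[C@H]1CC[C@H](CNc2cc(NCc3cnccc3C(F)(F)F)ncc2C#N)CC1` gives 330 nM and lies within the scatter of it, while compound 3 `CC(C)(F)c1ncncc1CNc1cc(N[C@H]2CC[C@@H](O)CC2)c(C#N)cn1`, which gives 32 nM, sits well beyond. The step from compound 1 to compound 2, a 1.2-fold higher number from compound 1 to compound 2 (0.08 log units; within the scatter), exchanged one saturated ring for another at the same nitrogen and barely moved the number. Compound 4 `CC1(C)[C@@H](Nc2cc(NCc3cnccc3C(F)(F)F)ncc2C#N)C[C@H]1C(N)=O` makes a larger change at that nitrogen: 3-carbamoyl-2,2-dimethylcyclobutyl in place of (oxan-4-yl)methyl on a nitrogen on an aromatic ring. For the measured compounds named here, no measured step isolates this change; the only step at that nitrogen was small, and compound 3, whose ring sits on the nitrogen itself, reaches a low number, though its core differs too. Compound 4 is therefore expected to improve modestly, a 2.0-fold lower number from compound 2 to compound 4 (0.30 log units; within the scatter), to an estimated 200 nM, with a range from 50 nM to 800 nM.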

Compound 4, half-maximal inhibitory concentration: 140 nM
The estimate for compound 4 lay 1.4-fold (0.15 log units) above the measured number, within the range that was stated.
By their numbers in this assay, from the lowest: compound 3; then compound 4; then compounds 1 and 2 (each within the scatter of the next).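

At the nitrogen on an aromatic ring, exchanging one saturated ring for another had left the number within the scatter, but 3-carbamoyl-2,2-dimethylcyclobutyl produces steps beyond it, with a 2.9-fold lower number from compound 2 to compound 4 (0.46 log units; beyond the scatter) and a 2.4-fold lower number from compound 1 to compound 4 (0.37 log units; beyond the scatter) on the shared core. This position therefore responds to the group it carries, though both steps are modest. Nothing available explains the change.

Going by these compounds, the carbamoyl group and the dimethylcyclobutyl ring enter together, so their separate shares remain unknown. On these data alone, whether a carboxylic acid in place of the carbamoyl, or a cyclobutyl without the two methyl groups, would hold the number stays open.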